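Amine replacement on the shared core: outlook for compound 3

A few compounds are considered here, and "the series" means these few. Any claim that something is new, unique, unknown or untested is made for them only; others in the source may bear on it.

Measured compounds:
compound 1 `NS(=O)(=O)OC[C@@H]1C[C@@H](Nc2ncnc(N[C@H]3CCc4ccccc43)c2F)C[C@@H]1O` gives 219 nM in an assay on a protein complex for inhibition of NEDD8 activating enzyme (Homo sapiens), read by HTRF, with a stated time of 2 h, in the presence of a further agent that is not named here; on this read-out higher numbers stand for weaker inhibition and lower numbers for stronger inhibition
compound 2 `NS(=O)(=O)OC[C@@H]1C[C@@H](n2nnc3c(NCc4cccs4)ncnc32)C[C@@H]1O` gives 15.9 nM in this assay

Of the two compounds measured in this assay, compound 2 gives the lowest number; compound 1 sits at a higher number, and the gap between them lies beyond the usual scatter. Compound 3 `COC(=O)[C@H]1C=C[C@@H](Nc2ncnc3c2nnn3[C@@H]2C[C@@H](COS(N)(=O)=O)[C@@H](O)C2)C1`, not yet measured, differs from compound 2 by a group of 9 heavy atoms (7 carbon, 2 oxygen; one five-membered non-aromatic ring of carbon only) in place of a group of 6 heavy atoms (5 carbon, 1 sulfur; one five-membered aromatic ring with 1 hetero atom), on a nitrogen on an aromatic ring. Among the measured compounds shown here, no measured pair shows this change, so nothing in the data fixes its size or direction. The step from compound 2 to compound 3 in this assay is expected to run toward a higher number, of moderate size and probably beyond the scatter, as a 3.8-fold higher number from compound 2 to compound 3 (0.58 log units; beyond the scatter). For the measured compounds named here, with no measured analogue for this change, the range is kept wide. For compound 3 the estimate in this assay is 60 nM, with a range from 15 nM to 250 nM.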

Compound 3, half-maximal inhibitory concentration: 80.9 nM
Estimate against measurement, compound 3: 1.3-fold (0.13 log units) below; the measured number falls inside the stated range.
By their numbers in this assay, from the lowest: compound 2; then compound 3; then compound 1.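

In this assay, this nitrogen on an aromatic ring now has its first measured change, a 5.1-fold higher number from compound 2 to compound 3 (0.71 log units; beyond the scatter), as the (thiophen-2-yl)methyl group gives way to a group of 9 heavy atoms built on a five-membered non-aromatic ring of carbon only. The step is modest, and a group with no aromatic ring and 2 defined stereocentres still leaves compound 3 at 80.9 nM, so an aromatic ring in this group is not a requirement for a measurable value. Nothing available bears on the cause of this step.

Ring, double bonds, ester and stereocentres all change in this single step, so their separate shares cannot be read. On these data alone, whether a carboxylic acid in place of the methyl ester, or a plain cyclopentyl group, would lower or raise the number remains open.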